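This account rests on a few compounds, and the source may have more. Where it says the series, first, only, none or still open, it means among the compounds named here.

Compound 1 `O=S(=O)(c1cccc2ncccc12)N1CCC(CCN2CCN(c3ccccc3)CC2)CC1`: 209 nM in an assay on HEK293 cells for displacement of a labelled ligand from 5-hydroxytryptamine receptor 7 (Homo sapiens), read by scintillation counting, with a stated time of 1 h; a higher number here means a weaker inhibitor, a lower number a stronger inhibitor
Compound 2 `O=S(=O)(c1cccc2ncccc12)N1CCC(CCN2CCN(c3ccc(Cl)cc3)CC2)CC1`: 37 nM

Among these two numbers, compound 1 stands highest, with compound 2 the only neighbour; the step of a 5.6-fold lower number from compound 1 to compound 2 (0.75 log units; beyond the scatter) is the one measured change. Compound 3 `O=S(=O)(c1cccc2ncccc12)N1CCC(CCN2CCN(c3cccc(Cl)c3Cl)CC2)CC1` arises from compound 1 by the change (2,3-dichlorophenyl in place of phenyl on an amine nitrogen in a ring). That single measured step, which also placed chlorine on this ring, points to a lower number, so a modest fall beyond the scatter is expected for compound 3, and the expected step of a 3.5-fold lower number from compound 1 to compound 3 (0.54 log units; beyond the scatter) reflects this. For compound 3 the estimated value is 60 nM, within a range from 15 nM to 200 nM.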

Compound 3, inhibition constant: 55 nM
Compound 3: the middle estimate sits 1.1-fold (0.04 log units) above what was measured; measured number inside the range.
By their numbers in this assay, from the lowest: compounds 2 and 3 (each within the scatter of the next); then compound 1.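

Putting 2,3-dichlorophenyl in place of phenyl gives a 3.8-fold lower number from compound 1 to compound 3 (0.58 log units; beyond the scatter) and shows that the gain from chlorine at this position is not limited to 4-chlorophenyl. Set against 4-chlorophenyl, the same group gives a 1.5-fold higher number from compound 2 to compound 3 (0.17 log units; within the scatter) and so the two chlorinated compounds cannot be told apart, which means a second chlorine brings no measurable difference here. Nothing shown explains why chlorine on this ring matters. Still open, going by these compounds, is whether other groups on this ring, such as fluoro, methyl or methoxy, would match chlorine.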